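This account rests on a few compounds, and the source may have more. Where it says the series, first, only, none or still open, it means among the compounds named here.

Compound 1, `Oc1ccc(O)c(COCc2cc(O)cc(Cl)c2O)c1`: 5800 nM
Compound 2, `COCc1cc(O)c(Cc2cc(O)ccc2O)cc1O`: 5800 nM

In a functional assay on MOLT-4 cells (Homo sapiens) for cytotoxicity, read by MTT assay (on this read-out higher numbers stand for weaker inhibition and lower numbers for stronger inhibition), compound 1 gives 5800 nM. In this assay compound 2 gives 5800 nM, which is level with compound 1 at the digits shown, a gap within the scatter. Compound 3, `COCc1cc(O)c(Cc2cc(O)c(Cc3cc(O)ccc3O)cc2O)cc1O`, has not yet been measured. It differs from compound 2 by 2,5-dihydroxybenzyl in place of hydrogen on an aromatic carbon. Going by the values given here, no step between measured compounds is available to size this kind of change, so nothing more than a small step, not beyond the scatter, is expected from compound 2 to compound 3, namely a 1.5-fold lower number from compound 2 to compound 3 (0.16 log units; within the scatter). For compound 3 the expected value is 4000 nM, with a range from 1500 nM to 12000 nM.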

Compound 3, half-maximal inhibitory concentration: 5500 nM
Compound 3: the middle estimate sits 1.4-fold (0.14 log units) below what was measured; measured number inside the range.
By their numbers in this assay, from the lowest: compounds 3, 1 and 2 (each within the scatter of the next).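

Placing 2,5-dihydroxybenzyl on this aromatic carbon, ortho to a hydroxy group, gives a 1.1-fold lower number from compound 2 to compound 3 (0.02 log units; within the scatter) in this assay. This position therefore takes a group carrying a whole extra aromatic ring, and the number stays level with that of compound 2. Nothing measured here explains this result. As far as these compounds go, whether an amine, a carboxylic acid or a longer alkyl chain on the same carbon would also leave the number level remains open. A single change at a single position also cannot show whether other positions on the core would respond in the same way.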